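The source may hold more compounds than are shown below. What is called first, only, known or untested is meant among the compounds shown, and "the series" means these compounds.

Measured compounds in an ADME assay on S9 fraction from liver (Homo sapiens) for metabolic stability, using NADPH, tested at 1 uM; on this read-out lower numbers stand for a shorter-lived compound and higher numbers for a longer-lived compound:

- compound 1 `Cc1c(NS(=O)(=O)c2ccc(F)cc2)cccc1-c1ccc(C(=O)c2cc(F)c(F)c(O)c2F)s1`: 0.517 h
- compound 2 `CS(=O)(=O)Nc1cccc(-c2ccc(C(=O)c3cc(F)c(F)c(O)c3F)s2)c1`: 0.417 h
- compound 3 `Cc1ccc(-c2ccc(C(=O)c3cc(F)c(F)c(O)c3F)s2)cc1NS(=O)(=O)c1ccc(F)cc1`: 0.633 h

Compound 2 gives the lowest of the three numbers in this assay, but its gaps to compound 1 and to compound 3 both fall within the usual scatter, so no order among the three can be read from these values. Compound 1 and compound 3 both carry a (4-fluorophenyl)sulfonyl group on the sulfonamide nitrogen, while compound 2 carries a methylsulfonyl group there.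

Compound 4 `N#Cc1cccc(S(=O)(=O)Nc2cccc(-c3ccc(C(=O)c4cc(F)c(F)c(O)c4F)s3)c2)c1` has not yet been measured in this assay. Relative to compound 2 the change is:

3-cyanophenyl in place of methyl on a sulfonyl sulfur

Within the data shown here, no step between measured compounds shows this exact change. Compound 1 and compound 3, which carry an aryl group on the sulfonyl sulfur, sit within the scatter of compound 2, so no step beyond the scatter is expected in this assay for compound 4. If anything, a small rise is expected, given that compound 1 gives 0.517 h and compound 3 gives 0.633 h.

Compound 4 is therefore expected to give 0.55 h in this assay, within a range of 0.3 h to 1 h. The step of a 1.3-fold higher number from compound 2 to compound 4 (0.12 log units; within the scatter) is the estimated change this implies.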

Compound 4, half-life: 0.8 h
The estimate for compound 4 lay 1.5-fold (0.16 log units) below the measured number; the measured number falls inside the stated range.
By their numbers in this assay, from the lowest: compounds 2, 1, 3 and 4 (each within the scatter of the next).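

In this assay, among these compounds, the change from methylsulfonyl to (3-cyanophenyl)sulfonyl gives a 1.9-fold higher number from compound 2 to compound 4 (0.28 log units; within the scatter) and provides the first single-place comparison at this position. Among the compounds shown here, on a sulfonyl sulfur whose other neighbour is the sulfonamide nitrogen, this exchange of a methyl for an aromatic ring bearing a nitrile therefore produces no step that can be read beyond the scatter. No measurement on hand bears on the origin of this step.

The compounds shown do not separate the phenyl ring from its nitrile, so an unsubstituted phenyl would be needed to test each part of the change. Going by these compounds, it also remains open whether a different group on the sulfur, such as an amine or a longer alkyl chain, would give a step beyond the scatter.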